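Working notes: hydroxypiperidine amide in place of dimethylpyrrolidine amide

The source may hold more compounds than are shown below. What is called first, only, known or untested is meant among the compounds shown, and "the series" means these compounds.

Two compounds of the series have been put through an ADME assay on Caco-2 cells (Homo sapiens) for permeability, read by LC-MS, in the apical to basolateral direction, with a stated time of 2 h; a higher number here means that the compound crosses the layer faster, a lower number that the compound crosses the layer more slowly. Compound 1 `O=C(NCc1cccc(Cl)c1)c1ccc2cn(CCN3CCOC3=O)nc2c1` gives 62 nm/s in this assay. Compound 2 `COc1cc(C(=O)N2CCCC2(C)C)cc2nc(NCc3cccc(Cl)c3)oc12` shares the chlorobenzylamine arm but carries a different core and a pyrrolidine amide; for compound 2 this assay gave "not determined" (no result reported), so the compound stands without a number in this assay and offers no anchor of its own.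

Compound 3 `COc1cc(C(=O)N2CC[C@@H](O)[C@H](C)C2)cc2nc(NCc3cccc(Cl)c3)oc12` keeps the core of compound 2 and changes only the amide portion: 4-hydroxy-3-methylpiperidin-1-yl in place of 2,2-dimethylpyrrolidin-1-yl on a carbonyl carbon. Going by the values given here, no measured pair on this series isolates that change, so the size of the step cannot be read from the data. The expectation is a modest drop from where compound 2 would stand, with the step between compound 2 and compound 3 in this assay likely close to the usual scatter rather than far beyond it, the reading of compound 1 being the only measured point of reference. For compound 3 in this assay the estimated apparent permeability is 40 nm/s, expected to fall between 12 nm/s and 130 nm/s.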

Compound 3, apparent permeability: 126 nm/s
For compound 3 the middle estimate is 3.2-fold (0.50 log units) below the measured one, and the stated range covers the measured number.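

Going by these compounds alone, no step from compound 2 to compound 3 can be read in this assay. The compounds shown leave open how 4-hydroxy-3-methylpiperidin-1-yl and 2,2-dimethylpyrrolidin-1-yl compare on the shared core in this assay. Nothing at hand offers an explanation for the reading of compound 3.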